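The source may report more compounds than this note shows. Statements on the series, on what has been measured and on what is new or still open speak of the compounds shown alone.

Working notes on the series

All four compounds share one core; only the chain on the amide nitrogen and the substitution on the aromatic ring vary. Compound 1 `CCCCCCCCCCCCNC(=O)[C@@H]1CSC(c2cc(OC)c(OC)c(OC)c2)N1` is the reference. In an ADME assay on cells (Fibroblast, Homo sapiens) for antiproliferative activity, read by sulforhodamine B assay, with a stated time of 48 h (a higher number here means a weaker inhibitor, a lower number a stronger inhibitor), compound 1 gives 2400 nM. Compound 2 `CCCCCCCCCCCCCCNC(=O)[C@@H]1CSC(c2cc(OC)c(OC)c(OC)c2)N1` differs from compound 1 by ethyl in place of hydrogen on a saturated chain carbon, ten or more bonds along the chain from an amide-type nitrogen. In this assay compound 2 gives 2600 nM, the step being a 1.1-fold higher number from compound 1 to compound 2 (0.03 log units; within the scatter). Compound 3 `CCCCCCCCCCCCNC(=O)[C@@H]1CSC(c2ccc(OC)c(OC)c2)N1` differs from compound 1 by hydrogen in place of methoxy on an aromatic carbon, and this is also how the core of compound 3 differs from that of compound 1 for the pair considered below. In this assay compound 3 gives 4500 nM, the step being a 1.9-fold higher number from compound 1 to compound 3 (0.27 log units; within the scatter). Among the measured compounds shown here, no step is counted between compound 2 and compound 3; their two values lie within the scatter of each other, so no order is read between them.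

Compound 4 `CCCCCCCCCCCCCCNC(=O)[C@@H]1CSC(c2ccc(OC)c(OC)c2)N1` has not yet been measured. It differs from compound 3 by ethyl in place of hydrogen on a saturated chain carbon, ten or more bonds along the chain from an amide-type nitrogen, the same change as from compound 1 to compound 2, at a place described in the same words. That earlier step, a 1.1-fold higher number from compound 1 to compound 2 (0.03 log units; within the scatter), was within the scatter. For the measured compounds named here, the step from compound 3 to compound 4 is therefore expected to be of like size, a 1.1-fold higher number from compound 3 to compound 4 (0.04 log units; within the scatter), because the only measured instance of this change, a 1.1-fold higher number from compound 1 to compound 2 (0.03 log units; within the scatter), moved the number hardly at all. Compound 4 is thus estimated to give 4900 nM in this assay, with the expected range running from 2500 nM to 9500 nM.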

Compound 4, half-maximal inhibitory concentration: 2800 nM
Compound 4: middle estimate off by 1.8-fold (0.24 log units), on the high side; the range from low to high includes it.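

In this assay, ethyl in place of hydrogen on a saturated chain carbon, ten or more bonds along the chain from an amide-type nitrogen, gives a 1.6-fold lower number from compound 3 to compound 4 (0.21 log units; within the scatter), and this step cannot be told apart from the earlier one: the same change on two cores in this assay, a 1.1-fold higher number (0.03 log units; within the scatter) from compound 1 to compound 2 and a 1.6-fold lower number (0.21 log units; within the scatter) from compound 3 to compound 4, 1.7-fold (0.24 log units) apart, within the scatter of two such steps. Hydrogen in place of methoxy on an aromatic carbon, now read on the chain of compound 2, gives a 1.1-fold higher number from compound 2 to compound 4 (0.03 log units; within the scatter), and it too cannot be told apart from its earlier instance: the same change on two cores in this assay, a 1.9-fold higher number (0.27 log units; within the scatter) from compound 1 to compound 3 and a 1.1-fold higher number (0.03 log units; within the scatter) from compound 2 to compound 4, 1.7-fold (0.24 log units) apart, within the scatter of two such steps. Each change therefore carries between the two cores in this series without a difference that can be read, but every step here lies within the scatter and each comparison rests on a single pair, so this shows neither that the changes have no effect nor that they would carry to any other core.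

As far as these compounds go, it remains open whether the same holds for a much shorter chain, or for a chain ending in an amine or a carboxylic acid. The compounds shown also leave open what a hydroxy group or a fluorine in place of methoxy on the aromatic ring would do in this assay.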